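This account rests on a few compounds, and the source may have more. Where it says the series, first, only, none or still open, it means among the compounds named here.

Of the compounds shown here, two built on one shared core have been tested in a functional assay on A549 cells (Homo sapiens) for inhibition, read by MTT assay, with a stated time of 24 h; a lower number here means a stronger inhibitor, a higher number a weaker inhibitor. Compound 1, `CC1(C)[C@H]2CC[C@]1(C)N(Cc1cn(-c3ccccc3F)nn1)C(=O)C2`, carries a 2-fluorophenyl group on an aromatic nitrogen, and in this assay compound 1 gives 240 nM. Compound 2, `CC1(C)[C@H]2CC[C@]1(C)N(Cc1cn(-c3cccc(Cl)c3)nn1)C(=O)C2`, carries a 3-chlorophenyl group in the same place instead, and in this assay compound 2 gives 60 nM. Among the measured compounds shown here, the single measured step, a 4.0-fold lower number from compound 1 to compound 2 (0.60 log units; beyond the scatter), is the only guide so far, and it leaves compound 2 with the lower of the two numbers.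

Compound 3, `Cc1cccc(-n2cc(CN3C(=O)C[C@@H]4CC[C@@]3(C)C4(C)C)nn2)c1`, keeps everything in compound 2 except one change: methyl in place of chloro on an aromatic carbon. For the measured compounds named here, no measured step exchanges one substituent for another at a fixed place on that ring; the one step known changes both the halogen and its place at once, so it bears on this change only loosely, showing that the group on this ring can move the number by a modest amount. With the ring and the place unchanged, the expected step from compound 2 to compound 3 is a 1.3-fold higher number from compound 2 to compound 3 (0.12 log units; within the scatter), small enough to sit near the scatter. In this assay compound 3 is therefore estimated at 80 nM, most likely between 35 nM and 200 nM.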

Compound 3, half-maximal inhibitory concentration: 50 nM
Compound 3: the middle estimate sits 1.6-fold (0.20 log units) above what was measured; the range from low to high includes it.
By their numbers in this assay, from the lowest: compounds 3 and 2 (each within the scatter of the next); then compound 1.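

At the place meta to a large group on this ring, methyl in place of chloro gives a 1.2-fold lower number from compound 2 to compound 3 (0.08 log units; within the scatter) in this assay, so the two groups cannot be told apart here, even though one is a halogen and the other a carbon group. The lower number seen earlier is therefore not tied to chlorine alone, since the 3-methylphenyl group also separates clearly from the 2-fluorophenyl group, with a 4.8-fold lower number from compound 1 to compound 3 (0.68 log units; beyond the scatter). No measurement shown here offers an explanation for why chloro and methyl read alike at this place.

The compounds shown leave open whether the gap to compound 1 follows the place on the ring or the group itself, since compound 1 differs from compound 2 and compound 3 in both, and a 3-fluorophenyl compound on the same core would help to separate the two. Also open, as far as these compounds go, is whether this place accepts groups quite unlike chloro and methyl, such as an amine, a carboxylic acid or a longer chain, without a change beyond the scatter.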